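Moving the Acid and Swapping the Linker in a Bile Acid Receptor Agonist

The source may report more compounds than this note shows. Statements on the series, on what has been measured and on what is new or still open speak of the compounds shown alone.

Of the compounds shown here, three have been measured in a functional assay on HEK293 cells for agonist activity at Bile acid receptor (Homo sapiens); on this read-out lower numbers stand for an effect already at smaller amounts and higher numbers for an effect only at larger amounts of compound. Compound 1 `CC(C)c1onc(-c2c(Cl)cccc2Cl)c1COc1ccc(N(C)C(=O)c2ccc(C(=O)O)cc2)c(C(F)(F)F)n1` gives 316 nM. Compound 2 `Cc1cc(OCc2c(-c3c(Cl)cccc3Cl)noc2C(C)C)nc2ccccc12` gives 536 nM. Compound 3 `CC(Nc1ccc(C(=O)O)cc1)c1ccc(OCc2c(-c3c(Cl)cccc3Cl)noc2C2CC2)nc1C(F)(F)F` gives 333 nM. Compound 3 thus holds the second highest of the three numbers; its gap to compound 1 and its gap to compound 2 both lie within the usual scatter, so the three cannot be ranked against each other on these data.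

Compound 4 `CC(Oc1cccc(C(=O)O)c1)c1ccc(OCc2c(-c3c(Cl)cccc3Cl)noc2C2CC2)nc1C(F)(F)F` keeps the core of compound 3 and changes one group on it: 3-carboxyphenoxy in place of (4-carboxyphenyl)amino on a saturated chain carbon bound to an aromatic carbon and a saturated chain carbon. The carboxylic acid stays, but the ring carrying it is now joined through an oxygen rather than a nitrogen bearing a hydrogen, and the acid sits at the 3-position instead of the 4-position of that ring.

Among the measured compounds shown here, no step between measured compounds isolates this kind of change, so there is nothing to lean on beyond the three values themselves, which all sit close together. The step of a 1.5-fold higher number from compound 3 to compound 4 (0.18 log units; within the scatter) is therefore expected to be small, leaning toward a higher number, and not clearly beyond the scatter. Compound 4 is expected to give about 500 nM, with a likely range from 150 nM to 1700 nM.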

Compound 4, half-maximal effective concentration: 107 nM
Compound 4: middle estimate off by 4.7-fold (0.67 log units), on the high side; the measured number lies below the stated range.
By their numbers in this assay, from the lowest: compound 4; then compounds 1, 3 and 2 (each within the scatter of the next).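

Swapping (4-carboxyphenyl)amino for 3-carboxyphenoxy on a saturated chain carbon bound to an aromatic carbon and a saturated chain carbon gives, in this assay, a 3.1-fold lower number from compound 3 to compound 4 (0.49 log units; beyond the scatter). Among the compounds shown here, this is the first change here that can be read as a single step, and it shows that the group at this place can move the number beyond the usual scatter, even though the ring and the carboxylic acid both remain. No measurement here accounts for this step, so the data give no reason for it.

The swap alters two features at once, the atom linking the ring and the position of the acid on that ring, so the step cannot be assigned to either alone. The two mixed partners, 4-carboxyphenoxy and (3-carboxyphenyl)amino, would separate those two features, while a methylene link in place of the oxygen, or an amide in place of the carboxylic acid, would test how much of the gain survives further change at this place.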